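Cyclobutylamino for ethylamino on a second core

The compounds below may be only part of what the source reports. "The series", "measured", "known", "first", "only" and "open" are said of these compounds alone.

Measured so far:
Compound 1, `CCNc1nc(-c2ccccc2)nc2c1nnn2Cc1ccccc1Cl`: 463000000 nM
Compound 2, `Clc1ccccc1Cn1nnc2c(NC3CCC3)nc(-c3ccccc3)nc21`: 24000000 nM
Compound 3, `CCNc1nc(-c2ccccc2)nc2c1nnn2Cc1ccccc1`: 91000000 nM

These three compounds were tested in an assay on isolated protein for binding affinity to adenosine receptor A1 (Bos taurus); on this read-out higher numbers stand for weaker inhibition and lower numbers for stronger inhibition. In this assay compound 1 gives 463000000 nM, compound 2 gives 24000000 nM and compound 3 gives 91000000 nM. Two changes connect them. One is cyclobutyl in place of ethyl on a nitrogen on an aromatic ring; this change gave a 19-fold lower number from compound 1 to compound 2 (1.29 log units; beyond the scatter). The other is hydrogen in place of chloro on an aromatic carbon; this change gave a 5.1-fold lower number from compound 1 to compound 3 (0.71 log units; beyond the scatter).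

Compound 4, `c1ccc(Cn2nnc3c(NC4CCC4)nc(-c4ccccc4)nc32)cc1`, is not yet measured. It differs from compound 3 by cyclobutyl in place of ethyl on a nitrogen on an aromatic ring, the same change that was made from compound 1 to compound 2, on a core that differs by hydrogen in place of chloro on an aromatic carbon. A step of the same size is expected, because a 19-fold lower number from compound 1 to compound 2 (1.29 log units; beyond the scatter); in this assay compound 4 is therefore estimated at 5000000 nM, a step of an 18-fold lower number from compound 3 to compound 4 (1.26 log units; beyond the scatter), which rests on a single earlier pair, so the range is wide: 1500000 nM to 15000000 nM.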

Compound 4, inhibition constant: 5000000 nM
Compound 4: middle estimate and measured number agree at the digits printed; low and high end bracket the measured number.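

In this assay, cyclobutyl in place of ethyl gave an 18-fold lower number from compound 3 to compound 4 (1.26 log units; beyond the scatter), which closely matches the step seen on the core carrying chloro: the same change on two cores in this assay, a 19-fold lower number (1.29 log units; beyond the scatter) from compound 1 to compound 2 and an 18-fold lower number (1.26 log units; beyond the scatter) from compound 3 to compound 4, 1.1-fold (0.03 log units) apart, within the scatter of two such steps. Hydrogen in place of chloro gave a 4.8-fold lower number from compound 2 to compound 4 (0.68 log units; beyond the scatter), and this change also carried over: the same change on two cores in this assay, a 5.1-fold lower number (0.71 log units; beyond the scatter) from compound 1 to compound 3 and a 4.8-fold lower number (0.68 log units; beyond the scatter) from compound 2 to compound 4, 1.1-fold (0.03 log units) apart, within the scatter of two such steps. Across these four compounds, each change therefore had about the same effect whichever form the other part took, but this does not show why, nor that the same would hold on a different core or in another assay.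

Going by these compounds, it remains open whether cyclopentyl or a longer chain such as butyl in place of cyclobutyl would give a similar step. On these data alone, it is equally open whether fluoro or methoxy in place of chloro would carry over in the same way.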